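This account rests on a few compounds, and the source may have more. Where it says the series, first, only, none or still open, it means among the compounds named here.

Notes on the series. Compound 1 `CCCCNc1nc(N)nc2c1ncn2/C=C1/CC1(CO)CO` carries butylamino on the shared core. In an ADME assay on MOLT-3 cells (Homo sapiens) for cytotoxicity, with a stated time of 7 days (on this read-out higher numbers stand for lower toxicity in this test and lower numbers for higher toxicity in this test), compound 1 gives only the assay's limit, > 20000 nM. Compound 2 `CCCCCCCCSc1nc(N)nc2c1ncn2/C=C1/CC1(CO)CO` carries octylsulfanyl in its place. In this assay compound 2 likewise reaches only a limit, > 20000 nM. Among the measured compounds shown here, the one measured step, a step that the two limits leave unreadable from compound 1 to compound 2, therefore cannot be read for size or direction; what is known is the limit of > 20000 nM in this assay, at which 2 of the 2 values shown sit, so compound 2 stands at the limit of this assay with no number beneath it.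

Compound 3 `Nc1nc(OCc2ccccc2)c2ncn(/C=C3/CC3(CO)CO)c2n1` is the next member. The change from compound 2: benzyloxy in place of octylsulfanyl on an aromatic carbon. For the measured compounds named here, no measured step speaks to benzyloxy on this core; the only step at hand, from compound 1 to compound 2, is unreadable, and both values shown are limits. In this assay the expectation for compound 3 therefore rests on the limit of > 20000 nM in this assay, at which 2 of the 2 values shown sit, alone: a step that the limit leaves unreadable from compound 2 to compound 3 that is expected to stay within the scatter, most likely ending again at the limit. The estimate for compound 3 is 30000 nM, between 15000 nM and 80000 nM, with the assay most probably reporting only a limit once more.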

Compound 3, half-maximal cytotoxic concentration: > 20000 nM
Compound 3: only a limit was reported (the forecaster's own chance of this, stated with the estimate: 80%); the middle value does not contradict the limit.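

Compound 3 gives only a limit in this assay, > 20000 nM, so the steps to it from compound 1 and compound 2 cannot be read for size or direction: the limit of > 20000 nM in this assay, at which 3 of the 3 values shown sit.

The compounds shown leave open whether any group at this place on the shared core gives a readable number in this assay.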